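The source may hold more compounds than are shown below. What is called first, only, known or untested is meant among the compounds shown, and "the series" means these compounds.

Compound 1 `COc1cc2c(Nc3ccc(C#N)cc3)ncnc2cc1OCCCN(C)Cc1ccccc1`: in a functional assay on HepG2 cells (Homo sapiens) for antiproliferative activity, read by MTT assay, with a stated time of 72 h (on this read-out lower numbers stand for stronger inhibition and higher numbers for weaker inhibition), compound 1 gives > 100000 nM, which is a limit of the assay, not a number.
Compound 2 `COc1cc2c(Nc3ccc(C#N)cc3)ncnc2cc1OCCCN1CCC(CO)CC1`: in this assay compound 2 gives 61800 nM.

Going by the values given here, compound 2 thus holds the only number in this assay; the other value is a limit (the limit of > 100000 nM in this assay, at which 1 of the 2 values shown sits). Among the compounds with values here, the one step measured, an at least 1.6-fold lower number from compound 1 to compound 2 (0.20 log units; that floor lies within the scatter), rests on that limit and does not reach beyond the scatter. Compound 3 `CCOC(=O)C1CCN(CCCOc2cc3ncnc(Nc4ccc(C#N)cc4)c3cc2OC)CC1` differs from compound 2 by ethoxycarbonyl in place of hydroxymethyl on a saturated ring carbon. The measured step alters the amine end of the chain, not this ring carbon, so it gives no guide to direction. The step expected in this assay is therefore none beyond the scatter, a 1.0-fold lower number from compound 2 to compound 3 (0.01 log units; within the scatter). Compound 3 is estimated at 60000 nM, between 20000 nM and 150000 nM.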

Compound 3, half-maximal inhibitory concentration: 57700 nM
Compound 3: the middle estimate sits 1.0-fold (0.02 log units) above what was measured, and the stated range covers the measured number.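

In this assay, ethoxycarbonyl in place of hydroxymethyl on this saturated ring carbon brings no change beyond the scatter (a 1.1-fold lower number from compound 2 to compound 3 (0.03 log units; within the scatter)), even though the entering group is larger and has no hydrogen-bond donor. The value of compound 1 is a limit, not a number. The step from it (an at least 1.7-fold lower number from compound 1 to compound 3 (0.23 log units; that floor lies within the scatter)) therefore shows no separation beyond the scatter for 4-(ethoxycarbonyl)piperidin-1-yl over benzyl(methyl)amino.

Still open, on these data alone, is whether a carboxylic acid or an aminomethyl group on this ring carbon would move the number beyond the scatter.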